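Swapping One Aryl Group on a Shared Core

A few compounds are considered here, and "the series" means these few. Any claim that something is new, unique, unknown or untested is made for them only; others in the source may bear on it.

In a functional assay on A2780 cells (Homo sapiens) for antiproliferative activity, read by MTT assay, with a stated time of 48 h (a lower number here means a stronger inhibitor, a higher number a weaker inhibitor), compound 1 `COc1ccc(-c2cc3c(cn2)[nH]c(=O)n3-c2cc(OC)c(OC)c(OC)c2)cc1F` gives 730 nM and compound 2 `COc1ccc(-c2cc3c(cn2)[nH]c(=O)n3-c2cc(OC)c(OC)c(OC)c2)cn1` gives 990 nM, so these two values lie within the usual scatter of each other. Compound 3 `CCOc1ccc(-c2cc3c(cn2)[nH]c(=O)n3-c2cc(OC)c(OC)c(OC)c2)cc1F` keeps the shared core and changes one group relative to compound 2: 4-ethoxy-3-fluorophenyl in place of 6-methoxypyridin-3-yl on an aromatic carbon. Within the data shown here, the one measured step, a 1.4-fold higher number from compound 1 to compound 2 (0.13 log units; within the scatter), exchanged 3-fluoro-4-methoxyphenyl for 6-methoxypyridin-3-yl and stayed within the scatter, so no change beyond the scatter is expected in this assay. The estimated step is a 1.4-fold lower number from compound 2 to compound 3 (0.15 log units; within the scatter). The expected value for compound 3 is 700 nM, with an estimated range of 300 nM to 1600 nM.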

Compound 3, half-maximal inhibitory concentration: 4330 nM
For compound 3 the middle estimate is 6.2-fold (0.79 log units) below the measured one; measured number above the stated range.
By their numbers in this assay, from the lowest: compounds 1 and 2 (each within the scatter of the next); then compound 3.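

In this assay, the change from methoxy to ethoxy gives a 5.9-fold higher number from compound 1 to compound 3 (0.77 log units; beyond the scatter) and so shows that methyl in place of hydrogen on this chain carbon can matter, though the earlier aryl exchange stayed within the scatter. Replacing 6-methoxypyridin-3-yl with 4-ethoxy-3-fluorophenyl gives a 4.4-fold higher number from compound 2 to compound 3 (0.64 log units; beyond the scatter) as well, with the ethoxy group as the feature that separates compound 3 from both earlier compounds. No available evidence explains this rise. Still open, on these data alone, is how a propoxy chain or an amine would fare here, and whether 6-ethoxypyridin-3-yl would behave like 4-ethoxy-3-fluorophenyl.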